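The source may hold more compounds than are shown below. What is called first, only, known or untested is meant among the compounds shown, and "the series" means these compounds.

In a functional assay for inhibition, with Homo sapiens as the target (a higher number here means a weaker inhibitor, a lower number a stronger inhibitor), compound 1 `CCOC(=O)/C(=C/c1cccc(OCC(=O)OC)c1)c1nc(-c2ccccc2)c(-c2ccccc2)o1` gives 19700 nM, while compound 2 `CCOC(=O)/C(=C\c1cccc(OCC(=O)OC)c1)c1nc(-c2ccccc2)c(-c2ccccc2)o1` gives 2000 nM. That is a 9.9-fold lower number from compound 1 to compound 2 (0.99 log units; beyond the scatter), a shift that arises because of the fact that compounds 1 and 2 differ only in the configuration as drawn. Compound 3 `CCOC(=O)C(Cc1cccc(OCC(=O)O)c1)c1nc(-c2ccccc2)c(-c2ccccc2)o1`, at 120 nM, has the lowest number of the three, and its gaps to both of the others lie beyond the scatter.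

Compound 4 `CC(C)(C)C(Cc1cccc(OCC(=O)O)c1)c1nc(-c2ccccc2)c(-c2ccccc2)o1` has not yet been measured. It differs from compound 3 in a single place, with tert-butyl in place of ethoxycarbonyl on a saturated chain carbon bound to an aromatic carbon and a saturated chain carbon.

For the measured compounds named here, no measured step swaps this group, so the evidence is thin. Going by the values given here, the only single-change step available, a 9.9-fold lower number from compound 1 to compound 2 (0.99 log units; beyond the scatter), concerns a double bond rather than this group. It bears on the question only by showing that one change in this set can move the number beyond the scatter, and it says nothing about direction here. Compound 3 is already the lowest of the three at 120 nM, so a cautious expectation in this assay is a move toward a higher number, no larger than that earlier step and quite uncertain. The estimate is therefore a 3.3-fold higher number from compound 3 to compound 4 (0.52 log units; beyond the scatter). For compound 4 the expected value is 400 nM, with an estimated range from 80 nM to 2500 nM.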

Compound 4, half-maximal inhibitory concentration: 3660 nM
The estimate for compound 4 lay 9.2-fold (0.96 log units) below the measured number; the whole stated range lies below it.
By their numbers in this assay, from the lowest: compound 3; then compounds 2 and 4 (each within the scatter of the next); then compound 1.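

In this assay, putting tert-butyl in place of ethoxycarbonyl on a saturated chain carbon bound to an aromatic carbon and a saturated chain carbon gives a 31-fold higher number from compound 3 to compound 4 (1.48 log units; beyond the scatter), so the number depends strongly on the group held at this position. The two groups are close in size by heavy-atom count, with 5 heavy atoms in ethoxycarbonyl and 4 in tert-butyl, yet they differ in makeup: ethoxycarbonyl brings 2 oxygen atoms, 1 double bond and 2 hydrogen-bond acceptors, while tert-butyl is all carbon with 0 hydrogen-bond acceptors. Similar heavy-atom count alone therefore does not keep the number in place here, and nothing measured in this set explains the step or singles out which of these differences matters.

Going by these compounds, a single swap gives no trend, so it remains open whether an amide, a nitrile or a methoxymethyl group at this position would keep the number near that of compound 3 or move it toward that of compound 4. On these data alone, it is also open whether a smaller all-carbon group such as methyl would behave like tert-butyl.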